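Swapping methoxy for trifluoromethyl on the outer ring

The compounds below may be only part of what the source reports. "The series", "measured", "known", "first", "only" and "open" are said of these compounds alone.

compound 1 `CCNc1cc(-c2ccc(NC(=O)Nc3ccc(C(F)(F)F)cc3)cc2C)ccn1`: 6870 nM
compound 2 `CCNc1cc(-c2ccc(NC(=O)Nc3ccc(OC)cc3)cc2OC)ccn1`: 17500 nM

In a functional assay on MCF7 cells (Homo sapiens) for cytotoxicity, read by MTT assay, with a stated time of 24 h (on this read-out lower numbers stand for stronger inhibition and higher numbers for weaker inhibition), compound 2 gives 17500 nM. This is the higher of the two numbers, and its gap to compound 1 lies beyond the scatter. Compound 3 `CCNc1cc(-c2ccc(NC(=O)Nc3ccc(C(F)(F)F)cc3)cc2OC)ccn1` keeps the rest of compound 2 but carries trifluoromethyl in place of methoxy on an aromatic carbon, para to a large group: trifluoromethyl in place of methoxy on an aromatic carbon. Within the data shown here, no measured pair shows this change on its own, so any expectation here is tentative. Among the measured compounds shown here, the only guide is compound 1, which also carries a 4-(trifluoromethyl)phenyl group and gives 6870 nM, and this points towards a lower number. The expected change is a modest drop, a 2.1-fold lower number from compound 2 to compound 3 (0.31 log units; beyond the scatter), near the edge of the scatter. For compound 3 the estimated value in this assay is 8500 nM, with an expected range from 4000 nM to 17000 nM.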

Compound 3, half-maximal inhibitory concentration: 19500 nM
For compound 3 the middle estimate is 2.3-fold (0.36 log units) below the measured one; the measured number lies above the stated range.
By their numbers in this assay, from the lowest: compound 1; then compounds 2 and 3 (each within the scatter of the next).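

In this assay, the change from 4-methoxyphenyl to 4-(trifluoromethyl)phenyl gives a 1.1-fold higher number from compound 2 to compound 3 (0.05 log units; within the scatter) and so makes no readable difference on this core, where the methoxy stays on the other ring. The step that does register is methoxy in place of methyl on an aromatic carbon, which gives a 2.8-fold higher number from compound 1 to compound 3 (0.45 log units; beyond the scatter) with the 4-(trifluoromethyl)phenyl group held fixed. Among these three compounds, then, the lower number goes with the methyl of compound 1 and not with the trifluoromethyl alone.

As far as these compounds go, it remains open whether an amine or a carboxylic acid on the outer ring, or an ethyl group in place of that methyl, would shift the number, and no data here explain either step.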